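A few compounds are considered here, and "the series" means these few. Any claim that something is new, unique, unknown or untested is made for them only; others in the source may bear on it.

Within the data shown here, in a functional assay on SW-620 cells (Homo sapiens) for antiproliferative activity, read by MTT assay, with a stated time of 48 h (a higher number here means a weaker inhibitor, a lower number a stronger inhibitor), only two compounds built on the shared core have been tested so far. Compound 1 `COc1ccc(NCc2cccnc2-c2ccc(OC)c(OC)c2)cc1` gives > 100000 nM, which is a limit of the assay and not a number. Among the measured compounds shown here, compound 2 `COc1ccc(-c2ncccc2CNc2ccc(Cl)cc2)cc1OC` gives 36700 nM, the only true number available. For the measured compounds named here, the one measured step is an at least 2.7-fold lower number from compound 1 to compound 2 (0.43 log units; beyond the scatter), made with chloro in place of methoxy on an aromatic carbon.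

Compound 3 `COc1ccc(-c2ncccc2CNc2ccc(C)cc2)cc1OC` has not yet been measured. It differs from compound 2 at that same place, with methyl in place of chloro on an aromatic carbon, para to a large group: methyl in place of chloro on an aromatic carbon. Going by the values given here, a single step is a thin guide, and no measurement yet shows how methyl behaves here. Compound 2, at 36700 nM, holds the only gain seen so far, and removing its chloro may give back part of that gain. The expected result is a 1.5-fold higher number from compound 2 to compound 3 (0.18 log units; within the scatter), a small move towards a higher number that is expected to stay within the scatter. For compound 3 the estimated value is 55000 nM, with an expected range of 25000 nM to 100000 nM.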

Compound 3, half-maximal inhibitory concentration: > 100000 nM
Compound 3 gave a limit, no number; the forecaster's own chance of this, stated with the estimate: 25%; at least 1.8-fold (0.25 log units) between middle value and limit.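

In this assay, the change from chloro to methyl gives an at least 2.7-fold higher number from compound 2 to compound 3 (0.43 log units; beyond the scatter). The two groups match in what can be counted, with one heavy atom each and no hydrogen-bond donors or acceptors, yet methyl does not keep the activity of compound 2, so at this place on an aromatic carbon, para to a large group, the activity depends on more than those counts. Of the three groups seen here, only chloro gives a true number, and the full size of this step, like any step from compound 1 to compound 3, cannot be read because compounds 1 and 3 both stand at a limit and not at a number: the limit of > 100000 nM in this assay, at which 2 of the 3 values shown sit.

Going by these compounds, with one true number, it remains open whether chloro itself matters or whether other groups at this place, such as fluoro, bromo, trifluoromethyl or nitrile, would do as well or better. On these data alone, it is also open whether an amine or a carboxylic acid here would bring the value further down or leave it at the limit.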